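Benzyl to Pentyl on a Selenium-Bearing Triazole Core

A few compounds are considered here, and "the series" means these few. Any claim that something is new, unique, unknown or untested is made for them only; others in the source may bear on it.

Compound 1 `O=c1c2ccccc2[se]n1-c1nc(SCc2ccccc2)n[nH]1`: > 50000 nM
Compound 2 `CC(C)CSc1n[nH]c(-n2[se]c3ccccc3c2=O)n1`: 33400 nM

In an ADME assay on L929 cells (Mus musculus) for antiproliferative activity, read by CCK-8 assay, with a stated time of 48 h (a higher number here means a weaker inhibitor, a lower number a stronger inhibitor), compound 1 gives > 50000 nM. For the measured compounds named here, that figure is a limit of the assay and not a number, a point on which the limit of > 50000 nM in this assay, at which 1 of the 2 values shown sits, is the only evidence. Compound 2 carries isopropyl in place of phenyl on a saturated chain carbon bound to a sulfur and gives 33400 nM in this assay. Going by the values given here, the one measured step, an at least 1.4-fold lower number from compound 1 to compound 2 (0.17 log units; that floor lies within the scatter), therefore starts from a limit, and its floor sits within the scatter of repeated runs, so it shows no change beyond the scatter.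

Compound 3 `CCCCCSc1n[nH]c(-n2[se]c3ccccc3c2=O)n1` has not yet been measured in this assay. It differs from compound 1 by butyl in place of phenyl on a saturated chain carbon bound to a sulfur. The measured step is the only one that bears on this change, and it offers no direction beyond the scatter; a number near that of compound 2, or again only a limit, seems the likeliest outcome. The step from compound 1 that is expected here is an at least 1.4-fold lower number from compound 1 to compound 3 (0.15 log units; that floor lies within the scatter). Compound 3 is thus estimated at 35000 nM, with a range from 15000 nM to 80000 nM.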

Compound 3, half-maximal inhibitory concentration: 33500 nM
The estimate for compound 3 lay 1.0-fold (0.02 log units) above the measured number; the range from low to high includes it.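

In this assay, for the compounds shown here, compound 2 and compound 3 give the first pair of real numbers at this position, and the step between them is a 1.0-fold higher number from compound 2 to compound 3 (0.00 log units; within the scatter), so exchanging the one chain for the other shows no change beyond the scatter. The other new step, an at least 1.4-fold lower number from compound 1 to compound 3 (0.17 log units; that floor lies within the scatter), repeats the earlier picture: it too starts from a limit, and its floor lies within the scatter, so phenyl and butyl at this place cannot be told apart. For compound 1, > 50000 nM is a limit of the assay and not a number, and the true size of the step from phenyl to a plain chain stays unread: the limit of > 50000 nM in this assay, at which 1 of the 3 values shown sits.

The compounds shown leave open whether any other group at this place, such as an amine, a carboxylic acid or a chain longer than pentyl, would move the number beyond the scatter in this assay. They also leave open how far compound 1 really lies from compound 3, as long as compound 1 is known only by its limit.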